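Removing a fluoro substituent on a thiophene-linked benzamidine series

The source may report more compounds than this note shows. Statements on the series, on what has been measured and on what is new or still open speak of the compounds shown alone.

Measured compounds:
Compound 1 `COc1cc(OC)cc(-c2ccc(-c3ccc(C(=N)N)c(F)c3)s2)c1` gives 1850 nM in a functional assay on UACC-257 cells (Homo sapiens) for inhibition, read by sulforhodamine B assay, with a stated time of 48 h; a higher number here means a weaker inhibitor of growth, a lower number a stronger inhibitor of growth.
Compound 2 `N=C(N)c1ccc(-c2ccc(-c3ccc(Cl)cc3)s2)cc1F` gives 1620 nM in this assay.
Compound 3 `N=C(N)c1ccc(-c2ccc(-c3ccc(Cl)cc3)s2)cc1` gives 310 nM in this assay.

Compound 1 and compound 2 share the amidine end but differ elsewhere; the difference between the two cores is not broken down here, and their values sit close together. From compound 2 to compound 3 the change is hydrogen in place of fluoro on an aromatic carbon, and it gave a 5.2-fold lower number from compound 2 to compound 3 (0.72 log units; beyond the scatter). Compound 4 `COc1cc(OC)cc(-c2ccc(-c3ccc(C(=N)N)cc3)s2)c1` carries the same change on the core of compound 1, namely (hydrogen in place of fluoro on an aromatic carbon). Because the step of a 5.2-fold lower number from compound 2 to compound 3 (0.72 log units; beyond the scatter) was clear, compound 4 is expected to show a comparable step, a 4.6-fold lower number from compound 1 to compound 4 (0.67 log units; beyond the scatter). Compound 4 is therefore estimated at 400 nM, most likely between 150 nM and 1100 nM.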

Compound 4, concentration for 50% growth inhibition: 2760 nM
The estimate for compound 4 lay 6.9-fold (0.84 log units) below the measured number, outside the stated range (above it).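

On the core of compound 1, putting hydrogen in place of fluoro gave a 1.5-fold higher number from compound 1 to compound 4 (0.17 log units; within the scatter), so in this assay the two cannot be told apart. The same change therefore does not act alike on the two cores: the same change on two cores in this assay, a 5.2-fold lower number (0.72 log units; beyond the scatter) from compound 2 to compound 3 and a 1.5-fold higher number (0.17 log units; within the scatter) from compound 1 to compound 4, 7.8-fold (0.89 log units) apart, beyond the scatter of two such steps

Among the compounds shown here, this shows that the result on one core was no safe guide to the other, but with only one pair per core it does not show why they part ways. The compounds shown leave open how a methyl group or an amine on that same aromatic carbon would behave on each core. They also leave open whether a third core would follow either pair.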